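Sulfonylating the ring nitrogen of compound 2

The compounds below may be only part of what the source reports. "The series", "measured", "known", "first", "only" and "open" are said of these compounds alone.

Compound 1 (`CN1C/C(=C\c2cccnc2)C(=O)/C(=C/c2cc([N+](=O)[O-])ccc2F)C1`): 6170 nM
Compound 2 (`O=C1/C(=C/c2cccnc2)CNC/C1=C\c1ccccc1F`): > 20000 nM

In a functional assay on SMMC-7721 cells (Homo sapiens) for cytotoxicity, read by MTT assay, with a stated time of 24 h (on this read-out higher numbers stand for weaker inhibition and lower numbers for stronger inhibition), compound 2 stands only at a limit (> 20000 nM), not at a number. Compound 3 (`O=C1/C(=C/c2cccnc2)CN(S(=O)(=O)c2ccc(Br)cc2)C/C1=C\c1ccccc1F`) carries (4-bromophenyl)sulfonyl in place of hydrogen on an amine nitrogen in a ring. Within the data shown here, no measured pair isolates this change. Among the measured compounds shown here, the only guide is compound 1 (6170 nM), which has a methyl group on that nitrogen but also differs elsewhere. The expected step (an at least 3.3-fold lower number from compound 2 to compound 3 (0.52 log units; beyond the scatter)) points to stronger inhibition, beyond the usual scatter. Compound 3 is estimated at 6000 nM (from 1800 nM to 20000 nM).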

Compound 3, half-maximal inhibitory concentration: 9100 nM
For compound 3 the middle estimate is 1.5-fold (0.18 log units) below the measured one; low and high end bracket the measured number.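

In this assay the ring nitrogen of compound 2 now has a measured single change: (4-bromophenyl)sulfonyl in place of hydrogen gives an at least 2.1-fold lower number from compound 2 to compound 3 (0.34 log units; beyond the scatter) and so stronger inhibition. The change thus helps at this position, which compound 1 could not show, as it also differs elsewhere. On these data alone, the true size of the step stays unknown because compound 2 is recorded only as a limit: the limit of > 20000 nM in this assay, at which 1 of the 3 values shown sits.

As far as these compounds go, whether the sulfonyl link or the bromine matters more stays open. So does how an acetyl or benzyl group on this nitrogen would compare.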